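Furan-2-yl in Place of Iodo on a Shared Core

This account rests on a few compounds, and the source may have more. Where it says the series, first, only, none or still open, it means among the compounds named here.

Measured compounds:
compound 1, `COc1ncnc2c1c(-c1ccoc1)cn2[C@@H]1O[C@H](CO)[C@@H](O)[C@H]1O`: 29400 nM
compound 2, `COc1ncnc2c1c(I)cn2[C@@H]1O[C@H](CO)[C@@H](O)[C@H]1O`: 63000 nM

Among the measured compounds shown here, in an ADME assay on MRC5 cells (Homo sapiens), read by MTT assay, with a stated time of 72 h (a higher number here means a weaker inhibitor, a lower number a stronger inhibitor), compound 2 gives 63000 nM, the higher of the two numbers measured so far. Compound 1 gives 29400 nM. For the measured compounds named here, the only step known is a 2.1-fold higher number from compound 1 to compound 2 (0.33 log units; beyond the scatter), a modest rise that lies beyond the scatter.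

Compound 3, `COc1ncnc2c1c(-c1ccco1)cn2[C@@H]1O[C@H](CO)[C@@H](O)[C@H]1O`, is not yet measured. It differs from compound 2 as follows: furan-2-yl in place of iodo on an aromatic carbon. Going by the values given here, the one step that bears on this change is the step from compound 1 to compound 2, in which iodo took the place of a furan-3-yl group; the present change runs the other way, with a furan-2-yl group taking the place of iodo. Read in reverse, that step points to a modest fall in this assay, of about the same size, though the furan ring now sits attached through a different carbon, so a somewhat smaller or larger shift cannot be ruled out.

Compound 3 is therefore expected to show a 2.1-fold lower number from compound 2 to compound 3 (0.32 log units; beyond the scatter), giving an estimated 30000 nM with a range from 12000 nM to 80000 nM.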

Compound 3, half-maximal inhibitory concentration: 1700 nM
Compound 3: the middle estimate sits 18-fold (1.25 log units) above what was measured, and the stated range ends above it.
By their numbers in this assay, from the lowest: compound 3; then compound 1; then compound 2.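

In this assay, this aromatic carbon of the five-membered ring proved far more sensitive than the earlier pair had shown: furan-2-yl in place of iodo gives a 37-fold lower number from compound 2 to compound 3 (1.57 log units; beyond the scatter), a large step where the only earlier one, a 2.1-fold higher number from compound 1 to compound 2 (0.33 log units; beyond the scatter), was modest. The sharper finding lies between the two furans, for furan-2-yl in place of furan-3-yl gives a 17-fold lower number from compound 1 to compound 3 (1.24 log units; beyond the scatter), even though the same ring enters and only its point of attachment differs. Among these compounds, then, having a furan ring at this position does not by itself bring the large fall in the number, since compound 1 also carries one and stays much closer to compound 2, and no measurement available here accounts for the gap between the two furans.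

The compounds shown leave open whether the low number is particular to furan-2-yl or would also appear with another ring attached in the same way, such as thiophen-2-yl or a phenyl ring, or with an amine at this position. They also leave open whether the difference between the two furans would persist if an amine replaced the methoxy group on the shared core.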